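A few compounds are considered here, and "the series" means these few. Any claim that something is new, unique, unknown or untested is made for them only; others in the source may bear on it.

Compound 3 `OC[C@H]1O[C@@H](n2cnc3c(CSc4ccc(OC(F)(F)F)cc4)ncnc32)[C@H](O)[C@@H]1O` stands second highest of the three numbers in an assay on isolated protein for binding affinity to Equilibrative nucleoside transporter 1 (Homo sapiens); on this read-out higher numbers stand for weaker inhibition and lower numbers for stronger inhibition: compound 3 gives 123 nM. Its nearest neighbour is compound 2 `N#Cc1ccc(SCc2ncnc3c2ncn3[C@@H]2O[C@H](CO)[C@@H](O)[C@H]2O)cc1`, which gives 81.3 nM; the furthest is compound 1 `OC[C@H]1O[C@@H](n2cnc3c(CSc4ccccc4Cl)ncnc32)[C@H](O)[C@@H]1O`, which gives 1780 nM. The step of a 22-fold lower number from compound 1 to compound 2 (1.34 log units; beyond the scatter) was large, whereas the step of a 1.5-fold higher number from compound 2 to compound 3 (0.18 log units; within the scatter) stayed within the scatter.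

Compound 4 `COc1ccc(SCc2ncnc3c2ncn3[C@@H]2O[C@H](CO)[C@@H](O)[C@H]2O)cc1` differs from compound 3 by methyl in place of trifluoromethyl on an oxygen on an aromatic ring. Going by the values given here, no measured pair exchanges trifluoromethyl for methyl on an oxygen, so the two measured steps bear on this change only indirectly. The step of a 22-fold lower number from compound 1 to compound 2 (1.34 log units; beyond the scatter) shows that exchanging the substituent on the phenyl ring can move this assay by a large amount, but that exchange also altered the kind of substituent entirely. The step of a 1.5-fold higher number from compound 2 to compound 3 (0.18 log units; within the scatter) shows that exchanging cyano for trifluoromethoxy left this assay within the scatter, and this is the closer precedent, since compound 3 already carries the trifluoromethoxy that compound 4 trims to methoxy.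

The expectation is therefore a step of a 1.2-fold higher number from compound 3 to compound 4 (0.09 log units; within the scatter), that is, no movement beyond the scatter. For compound 4 the estimate in this assay is 150 nM, with a range from 50 nM to 500 nM.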

Compound 4, half-maximal inhibitory concentration: 617 nM
Beside the measured number, compound 4's estimate is 4.1-fold (0.61 log units) below it; the measured number lies above the stated range.
By their numbers in this assay, from the lowest: compounds 2 and 3 (each within the scatter of the next); then compound 4; then compound 1.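

In this assay the result shows that, at this place on the phenyl ring, trifluoromethoxy and methoxy are not interchangeable: a 5.0-fold higher number from compound 3 to compound 4 (0.70 log units; beyond the scatter) is a step beyond the scatter, although cyano and trifluoromethoxy had stayed within it. Removing the three fluorine atoms from the trifluoromethyl group is thus enough to move the read-out, and methoxy also parts from cyano, with a 7.6-fold higher number from compound 2 to compound 4 (0.88 log units; beyond the scatter) as the step between them. The new group does not lose everything, however, since a 2.9-fold lower number from compound 1 to compound 4 (0.46 log units; beyond the scatter) still leaves the 4-methoxyphenyl on the sulfur on the stronger side of the 2-chlorophenyl, so this substituent gives an intermediate result among the four compounds.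

Nothing at hand accounts for the size of the step from trifluoromethoxy to methoxy. From the compounds shown here alone, it also remains open whether an amine, a carboxylic acid or a longer chain such as ethoxy at this place would group with the cyano and trifluoromethoxy compounds or with the methoxy compound, and whether a single fluorine on the methyl would recover part of the step.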